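The source may hold more compounds than are shown below. What is called first, only, known or untested is meant among the compounds shown, and "the series" means these compounds.

Compound 3 `O=C(CCN1CCC(Cc2ccccc2)CC1)Nc1ccccc1Cl` gives 0.2 ug/mL in an assay on ileum with histamine H1 receptor (Cavia porcellus) as the target (on this read-out higher numbers stand for weaker inhibition and lower numbers for stronger inhibition), and stands second highest of the three numbers; compound 2 `CCc1ccccc1NC(=O)CCN1CCC(Cc2ccccc2)CC1` gives 0.17 ug/mL, and compound 1 `Cc1ccccc1C(=O)NCCN1CCC(Cc2ccccc2)CC1` gives 0.4 ug/mL, both within the scatter of compound 3. The step to compound 4 `O=C(CCN1CCC(Cc2ccccc2)CC1)Nc1ccccc1F` is fluoro in place of chloro on an aromatic carbon. Among the measured compounds shown here, the only measured step at this position, a 1.2-fold higher number from compound 2 to compound 3 (0.07 log units; within the scatter), left the number within the scatter, and no step exchanging one halogen for another has been measured, so no movement beyond the scatter in this assay is expected for compound 4. Compound 4 is therefore estimated at 0.25 ug/mL, with a range of 0.1 ug/mL to 0.6 ug/mL, meaning an expected step of a 1.3-fold higher number from compound 3 to compound 4 (0.10 log units; within the scatter).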

Compound 4, half-maximal inhibitory concentration: 0.28 ug/mL
Estimate against measurement, compound 4: 1.1-fold (0.05 log units) below; low and high end bracket the measured number.
By their numbers in this assay, from the lowest: compounds 2, 3, 4 and 1 (each within the scatter of the next, the first and the last beyond it).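

In this assay, the only exchange of one halogen for another shown at this position (a 1.4-fold higher number from compound 3 to compound 4 (0.15 log units; within the scatter)) lies within the scatter, and so does the exchange of ethyl for fluoro (a 1.6-fold higher number from compound 2 to compound 4 (0.22 log units; within the scatter)). Ethyl, chloro and fluoro on this aromatic carbon, ortho to a large group, are therefore not told apart by this read-out. Nothing available bears on why this is so. The compounds shown leave open whether an amine, a carboxylic acid or a longer chain on this carbon would move the number beyond the scatter, and whether hydrogen in place of the halogen would do so.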